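Aryl ketone variation in a three-compound antiproliferative series

A few compounds are considered here, and "the series" means these few. Any claim that something is new, unique, unknown or untested is made for them only; others in the source may bear on it.

Measured compounds:
- compound 1, `COc1cc(Br)cc2c1OC(N)=C(C#N)C2CC(=O)c1ccc(Cl)cc1`, in a functional assay on MCF7 cells (Homo sapiens) for antiproliferative activity, read by sulforhodamine B assay, with a stated time of 72 h, tested at 30 uM (a lower number here means a stronger effect, a higher number a weaker effect of the compound at the concentration tested), gives 33.3%
- compound 2, `COc1cccc(C(=O)CC2C(C#N)=C(N)Oc3c(OC)cc(Br)cc32)c1`, in this assay gives 33.9%
- compound 3, `COc1cc(Br)cc2c1OC(N)=C(C#N)C2CC(=O)c1ccc(Br)cc1`, in this assay gives 33.1%

Compound 3 has the lowest of the three numbers, but its gaps to the others are both within the scatter: a number 0.2 percentage points lower from compound 1 to compound 3 (within the scatter) and a number 0.8 percentage points lower from compound 2 to compound 3 (within the scatter). Likewise a number 0.6 percentage points higher from compound 1 to compound 2 (within the scatter). The three aryl groups on the carbonyl carbon — 4-chlorophenyl, 3-methoxyphenyl, 4-bromophenyl — therefore cannot be told apart in this assay on these numbers.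

Compound 4 is `COc1cc(Br)cc2c1OC(N)=C(C#N)C2CC(=O)c1ccc(C)cc1`. Its difference from compound 3: methyl in place of bromo on an aromatic carbon. Going by the values given here, no measured pair swaps bromo for methyl, so the expectation rests on the measured aryl changes at the same carbonyl carbon, all of which stayed within the scatter, including the halogen swap a number 0.2 percentage points lower from compound 1 to compound 3 (within the scatter) and the ring-substituent swap a number 0.8 percentage points lower from compound 2 to compound 3 (within the scatter). On that basis the step of a number 0.9 percentage points higher from compound 3 to compound 4 (within the scatter) is expected to be none beyond the scatter. Compound 4 is therefore estimated at 34% in this assay, with a range from 24% to 45%.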

Compound 4, a percentage reported as activity, at one concentration (the size of the read-out at that concentration, not a potency): 52.8%
For compound 4 the middle estimate is 18.8 percentage points below the measured one, outside the stated range (above it).
By their numbers in this assay, from the lowest: compounds 3, 1 and 2 (each within the scatter of the next); then compound 4.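

The aryl group on the carbonyl carbon is less tolerant of change than compound 1, compound 2 and compound 3 suggested: in this assay, 4-methylphenyl gives a weaker effect at the tested concentration than 4-bromophenyl, with a number 19.7 percentage points higher from compound 3 to compound 4 (beyond the scatter) for methyl in place of bromo, and methyl in place of chloro gives a number 19.5 percentage points higher from compound 1 to compound 4 (beyond the scatter) as well. Compound 4 also separates from the 3-methoxyphenyl analogue, with a number 18.9 percentage points higher from compound 2 to compound 4 (beyond the scatter) for that change of aryl group, so among these four compounds it alone stands apart, while the other three remain within the scatter of one another. Nothing shown here accounts for the separation of the methyl compound from the two halogen compounds.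

Going by these compounds, it remains open whether this shift is specific to methyl or extends to other non-halogen groups at this place on the ring, such as ethyl, methoxy, an amine or a carboxylic acid, and whether fluoro would track with chloro and bromo. With one tested concentration per compound, the read-out shows only whether the effect is stronger or weaker at that concentration and says nothing about the effect at any other.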